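The source may hold more compounds than are shown below. What is called first, only, known or untested is meant among the compounds shown, and "the series" means these compounds.

The account opens with compound 1, `CCC(CC)(c1ccc(OC[C@@H](O)CO)c(C)c1)c1ccc(OC[C@H](O)C(C)(C)OCCCCCCCCO)c(C)c1`, a diaryl ether bearing two glyceryl-type side chains. Among the measured compounds shown here, in an assay on HEK293 cells for agonist activity at vitamin D3 receptor (Homo sapiens), read by a beta-galactosidase reporter (on this read-out higher numbers stand for an effect only at larger amounts of compound and lower numbers for an effect already at smaller amounts), compound 1 gives 1200 nM, the only numerical value in this set; its companion, compound 2, `CCCCCCCCOC(C)(C)[C@H](O)COc1ccc(C(CC)(CC)c2ccc(OC[C@@H](O)CO)c(C)c2)cc1C`, gives "not active" (no number reported) in this assay, so compound 1 stands as the single compound with a measured potency here. Compound 3, `CCCCCCOC(C)(C)[C@@H](O)COc1ccc(C(CC)(CC)c2ccc(OC[C@@H](O)CO)c(C)c2)cc1C`, is the one still to be tested. Against compound 1 the change is hydrogen in place of 2-hydroxyethyl on a saturated chain carbon, six bonds along the chain from an oxygen on a saturated carbon. For the measured compounds named here, no measured pair in this set isolates that change, so the size of its effect cannot be read from a step; the outcome for compound 2, which also lacks a terminal hydroxyl on its chain, points toward a loss rather than a gain. Compound 3 is therefore expected to be weaker, with the step of a 3.3-fold higher number from compound 1 to compound 3 (0.52 log units; beyond the scatter) going beyond the usual scatter. For compound 3 the estimate in this assay is 4000 nM, within a range from 1200 nM to 20000 nM.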

Compound 3, half-maximal effective concentration: 1500 nM
Estimate against measurement, compound 3: 2.7-fold (0.43 log units) above; the measured number falls inside the stated range.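

In this assay, swapping 2-hydroxyethyl for hydrogen at this position gives a 1.3-fold higher number from compound 1 to compound 3 (0.10 log units; within the scatter), so the two compounds cannot be told apart on this read-out. The earlier compounds shown here could not show this: compound 3 has no terminal hydroxyl on its chain and still gives a measured potency, so the absence of that hydroxyl does not by itself mean a compound reads as not active. Nothing measured here offers an explanation for this tolerance.

On these data alone, it remains open whether the same tolerance would hold if a carboxylic acid or an amine ended the chain in place of the terminal hydroxyl. The compounds shown also do not isolate what separates the unnumbered result of compound 2 from the measured value of compound 3.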